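This account rests on a few compounds, and the source may have more. Where it says the series, first, only, none or still open, it means among the compounds named here.

Compound 2 `CC(C)[C@H]1NC(=O)[C@@H](Cc2ccccc2)NC(=O)[C@H](Cc2ccccc2)NC(=O)[C@H](COCc2ccccc2)NC(=O)[C@H](CC2CCCCC2)NC1=O` and compound 1 `CC(C)[C@H]1NC(=O)[C@@H](Cc2ccccc2)N(C)C(=O)[C@H](Cc2ccccc2)NC(=O)[C@H](COCc2ccccc2)NC(=O)[C@H](CC2CCCCC2)NC1=O` share one core. In a functional assay on HCT-116 cells (Homo sapiens) for cytotoxicity, read by hypoxanthine incorporation, with a stated time of 72 h, tested at 10 uM (on this read-out lower numbers stand for less inhibition of growth and higher numbers for more inhibition of growth at the one concentration tested), compound 2 gives 10%, while compound 1 gives 93%; the change between them, (methyl in place of hydrogen on an amide-type nitrogen in a ring), made a step of a number 83 percentage points higher from compound 2 to compound 1 (beyond the scatter). Compound 3 `CC(C)C[C@@H]1NC(=O)[C@H](Cc2ccccc2)NC(=O)[C@H](CCCCNC(=O)OC(C)(C)C)NC(=O)[C@H](CC(C)C)NC(=O)[C@H](C(C)C)NC1=O` has a different core; the difference between the two cores is not broken down here. In this assay compound 3 gives 0%. Compound 4 `CC(C)C[C@@H]1NC(=O)[C@H](Cc2ccccc2)NC(=O)[C@H](CCCCNC(=O)OC(C)(C)C)N(C)C(=O)[C@H](CC(C)C)NC(=O)[C@H](C(C)C)NC1=O` arises from compound 3 by the same kind of change, (methyl in place of hydrogen on an amide-type nitrogen in a ring); here the methyl sits next to the ring atom that bears a 4-((tert-butoxycarbonyl)amino)butyl group, whereas in compound 1 it sits next to the ring atom that bears a benzyl group. Resting on the large step of a number 83 percentage points higher from compound 2 to compound 1 (beyond the scatter) seen on a different core, a smaller and uncertain rise is expected, a number 40 percentage points higher from compound 3 to compound 4 (beyond the scatter). Compound 4 is expected to give 40%, between 0% and 90%.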

Compound 4, percent growth inhibition at one concentration: 58%
Beside the measured number, compound 4's estimate is 18 percentage points below it; low and high end bracket the measured number.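

In this assay the methyl in place of the amide hydrogen gives a number 58 percentage points higher from compound 3 to compound 4 (beyond the scatter) on this second core, so the direction of the change carries over between these two cores. The size does not carry over unchanged, and the two steps differ: the same change on two cores in this assay, a number 83 percentage points higher (beyond the scatter) from compound 2 to compound 1 and a number 58 percentage points higher (beyond the scatter) from compound 3 to compound 4, 25 percentage points apart, beyond the scatter of two such steps. Within the data shown here, with only two pairs, this does not separate the effect of the core from that of the methyl's place in the ring, and it shows nothing about other cores.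

Still open, from the compounds shown here alone, is whether a methyl on another amide nitrogen of the ring would give a similar rise. Also open, going by these compounds, is whether an ethyl on the same nitrogen, or a free amine in place of the 4-((tert-butoxycarbonyl)amino)butyl group, would retain it.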